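Series notes: removing the acetamido group from compound 1

This account rests on a few compounds, and the source may have more. Where it says the series, first, only, none or still open, it means among the compounds named here.

Going by the values given here, compound 1 `CC(=O)NC1CCN(c2ncnc3[nH]cc(-c4cccc(Cl)c4)c23)CC1` gives 1390 nM in an assay on HEK293T cells for displacement of a labelled ligand from Leucine-rich repeat serine/threonine-protein kinase 2 (Homo sapiens), read by NanoBRET, with a stated time of 2 h (on this read-out higher numbers stand for weaker inhibition and lower numbers for stronger inhibition), the lower of the numbers so far. Compound 2 `CNC1CCN(c2ncnc3[nH]cc(-c4cccc(Cl)c4)c23)CC1` gives 3540 nM in this assay. Among the compounds with values here, the single measured step is a 2.5-fold higher number from compound 1 to compound 2 (0.41 log units; beyond the scatter), which already shows that altering the substituent on this saturated ring carbon costs potency. Compound 3 `Clc1cccc(-c2c[nH]c3ncnc(N4CCCCC4)c23)c1` carries hydrogen in place of acetamido on a saturated ring carbon. Within the data shown here, this change touches the same position as the measured step but goes further, removing the whole group rather than trading acetyl for methyl, so the step from compound 1 is expected to run in the same direction and to be at least as large, because the only comparable step is a 2.5-fold higher number from compound 1 to compound 2 (0.41 log units; beyond the scatter). Whether the bare ring loses still more is not settled by the data. For compound 3 the expected step is a 3.2-fold higher number from compound 1 to compound 3 (0.51 log units; beyond the scatter). Compound 3 is therefore estimated at 4500 nM, with a range from 1500 nM to 14000 nM.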

Compound 3, half-maximal inhibitory concentration: 1140 nM
Compound 3: middle estimate off by 3.9-fold (0.60 log units), on the high side; the measured number lies below the stated range.
By their numbers in this assay, from the lowest: compounds 3 and 1 (each within the scatter of the next); then compound 2.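

In this assay, the step of a 1.2-fold lower number from compound 1 to compound 3 (0.09 log units; within the scatter) shows that the whole acetamido group on this saturated ring carbon can give way to hydrogen with no change beyond the scatter, so the bare ring matches the acetamido compound. Hydrogen in place of methylamino gives a 3.1-fold lower number from compound 2 to compound 3 (0.49 log units; beyond the scatter) and so the higher number belongs to the methylamino group itself, not to the loss of the acetamido group. The data at hand offer nothing that bears on why the methylamino group alone stands apart.

The compounds shown leave open whether a primary amine, a hydroxyl, a carboxylic acid or a longer amide chain on this carbon would move the number away from that of the bare ring. They also leave open whether the methylamino result extends to other amines.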